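The source may hold more compounds than are shown below. What is called first, only, known or untested is meant among the compounds shown, and "the series" means these compounds.

In a functional assay on HL60/MX2 cells (Homo sapiens) for antiproliferative activity, read by MTT assay, with a stated time of 48 h (on this read-out lower numbers stand for stronger inhibition and higher numbers for weaker inhibition), compound 1 (`CN(C)CCCn1c(N)c(-c2nc3ccccc3[nH]2)c2nc(C#N)c(C#N)nc21`) gives 2390 nM as its reading. Compound 2 (`N#Cc1nc2c(-c3nc4ccccc4[nH]3)c(N)n(CCCO)c2nc1C#N`) gives > 50000 nM in this assay, which is a limit of the assay and not a number. Within the data shown here, the one measured step, hydroxy in place of dimethylamino, is an at least 20-fold higher number from compound 1 to compound 2 (1.32 log units; beyond the scatter) and counts as large.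

Compound 3 (`CCN(CC)CCCCn1c(N)c(-c2nc3ccccc3[nH]2)c2nc(C#N)c(C#N)nc21`) departs from compound 2 by (diethylamino)methyl in place of hydroxy on a saturated chain carbon, three bonds along the chain from an aromatic nitrogen as its change: (diethylamino)methyl in place of hydroxy on a saturated chain carbon, three bonds along the chain from an aromatic nitrogen. Among the measured compounds shown here, that step, read in reverse, is the only one bearing on this change, so a large move to a lower number is expected. For the measured compounds named here, no measured compound tests the longer chain or the diethylamino end, which leaves compound 1 at 2390 nM as the nearest reference. The estimate is an at least 20-fold lower number from compound 2 to compound 3 (1.30 log units; beyond the scatter) as a large step. For compound 3 the expected value is 2500 nM, with an estimated range of 600 nM to 10000 nM in this assay.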

Compound 3, half-maximal inhibitory concentration: 1550 nM
Compound 3: the middle estimate sits 1.6-fold (0.21 log units) above what was measured; low and high end bracket the measured number.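

A second amine-ended chain gives an at least 32-fold lower number from compound 2 to compound 3 (1.50 log units; beyond the scatter) in this assay, so the gap from the hydroxy compound now holds for two amines and not just one. Between those two amines the step is a 1.5-fold lower number from compound 1 to compound 3 (0.19 log units; within the scatter), so in this pair, a longer chain combined with diethylamino in place of dimethylamino leaves the reading within the usual scatter. Compound 2 carries a limit of the assay and not a number, so the step from it is only a bound: the limit of > 50000 nM in this assay, at which 1 of the 3 values shown sits.

Chain length and the amine end change together in the one step between the amines, so their separate contributions remain unresolved. Still open, going by these compounds, is how a 3-(diethylamino)propyl chain would read, as it would split those two changes, and how a morpholine or a carboxylic acid at the chain end would compare.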